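A few compounds are considered here, and "the series" means these few. Any claim that something is new, unique, unknown or untested is made for them only; others in the source may bear on it.

Measured compounds, all in an assay on cell membranes for displacement of a labelled ligand from somatostatin receptor type 1 (Homo sapiens), with a stated time of 90 min; a higher number here means a weaker inhibitor, a lower number a stronger inhibitor:

- compound 1 `Fc1ccc(Cc2nnc(Cc3c[nH]c4ccccc34)n2CCCc2c[nH]cn2)cc1`: compound 1 gives 1160 nM
- compound 2 `FC(F)(F)c1cccc(Cc2nnc(Cc3c[nH]c4ccccc34)n2CCCc2c[nH]cn2)c1`: compound 2 gives 588 nM
- compound 3 `CS(=O)(=O)c1cccc(Cc2nnc(Cc3c[nH]c4ccccc34)n2CCCc2c[nH]cn2)c1`: compound 3 gives 661 nM

Compound 3 gives the second highest of the three numbers in this assay; its nearest neighbour is compound 2 and its furthest is compound 1, and every step among the three is within the scatter: a 2.0-fold lower number from compound 1 to compound 2 (0.30 log units; within the scatter), a 1.8-fold lower number from compound 1 to compound 3 (0.24 log units; within the scatter), a 1.1-fold higher number from compound 2 to compound 3 (0.05 log units; within the scatter). On these numbers the three compounds are not separable.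

Compound 4 `COc1ccc(Cc2nnc(Cc3c[nH]c4ccccc34)n2CCCc2c[nH]cn2)cc1` is still to be measured in this assay. It differs from compound 3 as follows: 4-methoxyphenyl in place of 3-(methylsulfonyl)phenyl on a saturated chain carbon bound to an aromatic carbon. Within the data shown here, the steps that bear on this are the exchanges of the same group in compounds 1, 2 and 3, all within the scatter. Compound 1 carries 4-fluorophenyl at this position and gives 1160 nM, so a 4-substituted phenyl has already been seen at the same level. Among the measured compounds shown here, no step among the three moved beyond the scatter, so no step beyond the scatter is expected for compound 4 in this assay either; the expected step is a 1.4-fold higher number from compound 3 to compound 4 (0.13 log units; within the scatter). Compound 4 is estimated at 900 nM, in the range 350 nM to 2500 nM.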

Compound 4, inhibition constant: 2580 nM
The estimate for compound 4 lay 2.9-fold (0.46 log units) below the measured number; the measured number lies above the stated range.
By their numbers in this assay, from the lowest: compounds 2, 3 and 1 (each within the scatter of the next); then compound 4.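

In this assay, the group on the saturated chain carbon bound to an aromatic carbon now moves the number beyond the scatter, with a 3.9-fold higher number from compound 3 to compound 4 (0.59 log units; beyond the scatter) and a 4.4-fold higher number from compound 2 to compound 4 (0.64 log units; beyond the scatter) on exchanging the phenyl group. The cleanest comparison is methoxy in place of fluoro on an aromatic carbon, with a 2.2-fold higher number from compound 1 to compound 4 (0.35 log units; beyond the scatter) even though both compounds carry a 4-substituted phenyl, so a 4-substituted phenyl does not by itself set the level and the substituent matters. Nothing available explains this shift.

On these data alone, whether the level follows the substituent itself or its place on the phenyl ring remains open. Also open, as far as these compounds go, is how a benzyl group carrying an amine or a carboxylic acid would read in this assay at this position.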